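The source may hold more compounds than are shown below. What is called first, only, known or untested is meant among the compounds shown, and "the series" means these compounds.

Of the compounds shown here, three with a shared core have been measured in a functional assay on A549 cells (Homo sapiens) for cytotoxicity, with a stated time of 48 h (a lower number here means a stronger inhibitor, a higher number a weaker inhibitor), so far. Compound 1 `CC(=O)Oc1ccc2oc(/C=C/[S+](C)[O-])cc(=O)c2c1` carries acetoxy and gives 4100 nM as its result. Compound 2 `C[S+]([O-])/C=C/c1cc(=O)c2ccccc2o1` has hydrogen in that place and gives 1900 nM as its result, while compound 3 `Cc1ccc2oc(/C=C/[S+](C)[O-])cc(=O)c2c1` has methyl there and gives 1700 nM as its result. Compound 2 thus stands level with compound 3 within the scatter, and modestly under compound 1 on the numbers. Compound 4 `COc1cccc2c(=O)cc(/C=C/[S+](C)[O-])oc12` has not been measured yet, and it differs from compound 2 by methoxy in place of hydrogen on an aromatic carbon in a single change, methoxy in place of hydrogen on an aromatic carbon. Going by the values given here, no measured compound carries methoxy, so only neighbouring steps can guide the expectation. Putting methyl in place of hydrogen gave a 1.1-fold lower number from compound 2 to compound 3 (0.05 log units; within the scatter) as its step, whereas a 2.2-fold lower number from compound 1 to compound 2 (0.33 log units; beyond the scatter) came with the loss of acetoxy. In this assay a small step or none beyond the scatter is therefore expected, leaning slightly towards a higher number. The estimate for compound 4 is 2300 nM with an expected range from 900 nM to 5500 nM across repeat measurements. That estimate would mean a 1.2-fold higher number from compound 2 to compound 4 (0.08 log units; within the scatter) as the expected step.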

Compound 4, half-maximal inhibitory concentration: 2200 nM
Compound 4: middle estimate off by 1.0-fold (0.02 log units), on the high side; measured number inside the range.
By their numbers in this assay, from the lowest: compounds 3, 2, 4 and 1 (each within the scatter of the next, the first and the last beyond it).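

In this assay, adding methoxy to an aromatic carbon ortho to a fused ring and meta to a fused ring gives a 1.2-fold higher number from compound 2 to compound 4 (0.06 log units; within the scatter), so this change leaves the number level with that of compound 2. Going by these compounds alone, this is a different ring carbon from the one carrying acetoxy in compound 1 and methyl in compound 3, so the result adds a new place on the shared core where a substituent is tolerated without a clear loss in this cytotoxicity read-out. No supporting measurement is available to explain why the number holds steady.

Going by these compounds, whether a longer chain such as butoxy, an amine or a carboxylic acid on this same carbon would shift the number beyond the scatter remains open. On these data alone, it is also open how methoxy would behave on the carbon that carries methyl in compound 3.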